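The compounds below may be only part of what the source reports. "The series", "measured", "known", "first", "only" and "open" are said of these compounds alone.

In an ADME assay on microsomes from liver (Mus musculus) for metabolic stability, read by LC-MS, with a stated time of 1 h, tested at 5 uM (on this read-out lower numbers stand for a less stable compound and higher numbers for a more stable compound), compound 1 `Cc1nc(-c2ccccc2F)c(C(=O)N2CCN(c3cc(Cl)cc(Cl)c3)CC2)o1` gives 49%, while compound 2 `Cc1nc(-c2ccccc2)c(C(=O)N2CCN(c3cccc(C#N)c3)CC2)o1` gives 1.6%, the lower of the two numbers and far beyond the scatter from compound 1. Compound 3 `COc1cc(OC)cc(N2CCN(C(=O)c3oc(C)nc3-c3ccccc3)CC2)c1` has not yet been measured in this assay. It differs from compound 2 in one place (3,5-dimethoxyphenyl in place of 3-cyanophenyl on an amine nitrogen in a ring). For the measured compounds named here, no measured pair shows a change of this kind, so no step can be drawn from the data. Any shift from compound 2 is expected to be small a number 3.4 percentage points higher from compound 2 to compound 3 (within the scatter), and compound 3 is estimated to give 5%, between 1% and 25%.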

Compound 3, percent of the compound remaining: 0.7%
For compound 3 the middle estimate is 4.3 percentage points above the measured one; the whole stated range lies above it.
By their numbers in this assay, from the lowest: compounds 3 and 2 (each within the scatter of the next); then compound 1.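

In this assay, placing 3,5-dimethoxyphenyl in place of 3-cyanophenyl on the amine nitrogen in the ring gives a number 0.9 percentage points lower from compound 2 to compound 3 (within the scatter). This single change, with its larger group and the nitrile gone, therefore leaves the read-out unresolved at this position, and compound 2 and compound 3 cannot be told apart. Nothing at hand accounts for this result.

Going by these compounds, it remains open whether a trifluoromethyl group or a carboxylic acid on this phenyl ring would move the number beyond the scatter. The higher number of compound 1 also cannot be assigned to this position, since that compound differs from compound 2 in more than one place.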